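Amide in place of acetamidomethyl on the isoxazole arm

The compounds below may be only part of what the source reports. "The series", "measured", "known", "first", "only" and "open" are said of these compounds alone.

Four compounds share one core, a resorcinol bearing an isopropyl group and two hydroxyls, joined to a five-membered ring that carries an ethylamide and a second five-membered ring whose substituent is varied. Compound 1 `CCNC(=O)c1noc(-c2cc(C(C)C)c(O)cc2O)c1-c1cc(CO)no1` bears a hydroxymethyl there, and in a functional assay on A2780 cells (Homo sapiens) for inhibition (a lower number here means a stronger inhibitor, a higher number a weaker inhibitor), compound 1 gives 5 nM. Compound 2 `CCNC(=O)c1noc(-c2cc(C(C)C)c(O)cc2O)c1-c1cc(CNC)no1` carries a methylaminomethyl group, and for compound 2 this assay reports "not determined" (no result reported). Compound 3 `CCNC(=O)c1noc(-c2cc(C(C)C)c(O)cc2O)c1-c1cc(CNC(C)=O)no1` carries an acetamidomethyl group, and in this assay compound 3 likewise has "not determined" (no result reported). Going by the values given here, compound 3 therefore stands without any number, and no comparison among the three can be drawn beyond the single value of compound 1.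

Compound 4 `CCNC(=O)c1noc(-c2cc(C(C)C)c(O)cc2O)c1-c1cc(C(=O)NC)no1` differs from compound 3 in one place: methylcarbamoyl in place of acetamidomethyl on an aromatic carbon. Among the compounds with values here, with no number for compound 3, the size and direction of this step in this assay cannot be anchored there; the only landmark is compound 1, and a carbonyl-linked amide in the position where compound 1 holds a hydroxymethyl is expected to hold potency in the same general region or a little weaker. Compound 4 is thus estimated at 20 nM, with a plausible range from 4 nM to 120 nM.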

Compound 4, half-maximal inhibitory concentration: 100 nM
Compound 4: middle estimate off by 5.0-fold (0.70 log units), on the low side, within the range that was stated.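

In this assay this position, on an aromatic carbon next to the ring nitrogen of the isoxazole arm, now shows that it responds to the choice of group: methylcarbamoyl in place of hydroxymethyl brings a 20-fold higher number from compound 1 to compound 4 (1.30 log units; beyond the scatter). Compound 1 at 5 nM thus remains the stronger inhibitor of the two, and a carbonyl-linked amide at this carbon does not keep its potency, although compound 4 at 100 nM still registers in the nanomolar range. Steps involving compound 2 or compound 3 cannot be read, so the acetamidomethyl to methylcarbamoyl change itself remains without a size, and nothing in hand accounts for the loss seen here.

The compounds shown leave open whether the step belongs to the carbonyl standing directly on the ring or to the methyl on the amide nitrogen, a question that an unsubstituted carbamoyl or an ethylcarbamoyl group would address. They also leave open how a carboxylic acid, a primary aminomethyl group or a longer hydroxyethyl chain at this carbon would compare with the hydroxymethyl of compound 1.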